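Methylsulfanyl in place of methyl: outlook for compound 4

This account rests on a few compounds, and the source may have more. Where it says the series, first, only, none or still open, it means among the compounds named here.

Compound 3 `Cc1ccccc1C(=O)Nc1sc2c(c1C(N)=O)CCN(C(=S)Nc1ccccc1Cl)C2` gives 20900 nM in a functional assay on HL-60 cells (Homo sapiens) for antiproliferative activity, with a stated time of 24 h (on this read-out higher numbers stand for weaker inhibition and lower numbers for stronger inhibition), the highest of the three numbers, yet within the scatter of compound 2 `NC(=O)c1c(NC(=O)c2ccccc2Br)sc2c1CCN(C(=S)Nc1ccccc1Cl)C2` at 14600 nM and of compound 1 `NC(=O)c1c(NC(=O)c2ccccc2F)sc2c1CCN(C(=S)Nc1ccccc1Cl)C2` at 12500 nM. The steps of a 1.2-fold higher number from compound 1 to compound 2 (0.07 log units; within the scatter), a 1.7-fold higher number from compound 1 to compound 3 (0.22 log units; within the scatter) and a 1.4-fold higher number from compound 2 to compound 3 (0.16 log units; within the scatter) all exchange the group on the same aromatic carbon, and none leaves the scatter. Compound 4 `CSc1ccccc1C(=O)Nc1sc2c(c1C(N)=O)CCN(C(=S)Nc1ccccc1Cl)C2` carries methylsulfanyl in place of methyl on an aromatic carbon. For the measured compounds named here, no measured step introduces a methylsulfanyl, so only the flat outcome of the three exchanges at this carbon bears on it, and no step beyond the scatter is expected in this assay. Compound 4 is therefore expected near 20000 nM, between 8000 nM and 50000 nM, the expected step being a 1.0-fold lower number from compound 3 to compound 4 (0.02 log units; within the scatter).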

Compound 4, half-maximal inhibitory concentration: 30500 nM
Compound 4: the middle estimate sits 1.5-fold (0.18 log units) below what was measured; measured number inside the range.
By their numbers in this assay, from the lowest: compounds 1, 2, 3 and 4 (each within the scatter of the next, the first and the last beyond it).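

Methylsulfanyl in place of methyl stays within the scatter in this assay with a 1.5-fold higher number from compound 3 to compound 4 (0.16 log units; within the scatter) and so does not separate the two groups. Methylsulfanyl in place of bromo gives a 2.1-fold higher number from compound 2 to compound 4 (0.32 log units; beyond the scatter) and in place of fluoro gives a 2.4-fold higher number from compound 1 to compound 4 (0.39 log units; beyond the scatter) and these modest steps are the only ones at this aromatic carbon to leave the scatter, so the position is not wholly flat. No measurement shown accounts for these steps. The compounds shown leave open how an amine, a carboxylic acid or a longer chain on this carbon would read in this assay and whether any group here would give a number well below that of compound 1.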